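The source may hold more compounds than are shown below. What is called first, only, known or untested is meant among the compounds shown, and "the series" means these compounds.

Compound 1 `CCC(C)/N=C(\C)c1c(O)c2ccccc2[nH]c1=O` carries a sec-butyl on the double-bonded nitrogen of the shared core. In an assay on isolated protein for inhibition of myosin-2 (Bos taurus), read by spectrophotometry, with a stated time of 24 min (on this read-out lower numbers stand for stronger inhibition and higher numbers for weaker inhibition), compound 1 gives >= 100000 nM, which is a limit of the assay and not a number. Compound 2 `C/C(=N\Cc1cccc(C)c1)c1c(O)c2ccccc2oc1=O` has a different core and a 3-methylphenyl on the saturated chain carbon bound to the double-bonded nitrogen. In this assay compound 2 gives 4900 nM. Compound 3 `C/C(=N\Cc1ccccc1C)c1c(O)c2ccccc2oc1=O` is its partner. In this assay compound 3 gives >= 100000 nM, again a limit of the assay. For the measured compounds named here, the single measured step, an at least 20-fold higher number from compound 2 to compound 3 (1.30 log units; beyond the scatter), puts 2-methylphenyl in place of 3-methylphenyl on the saturated chain carbon bound to a double-bonded nitrogen and ends at the limit of >= 100000 nM in this assay, at which 2 of the 3 values shown sit. That step concerns a different core and a ring-bearing group, so it bears only loosely on the change to compound 4 `CCCC/N=C(\C)c1c(O)c2ccccc2[nH]c1=O`, which is butyl in place of sec-butyl on a double-bonded nitrogen: the two have the same atoms joined differently. Going by the values given here, with compound 1 itself sitting at the limit and no measured step on this core, the expected step is a number no higher from compound 1 to compound 4 (the limit leaves the size open), none beyond the scatter. Compound 4 is therefore expected to give about 100000 nM in this assay, between 30000 nM and 300000 nM.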

Compound 4, half-maximal inhibitory concentration: >= 100000 nM
Compound 4: no number, only a limit; the forecaster's own chance of this, stated with the estimate: 70%; the middle value lies on the limit itself.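

In this assay compound 4 gives >= 100000 nM, a limit of the assay and not a number. For the compounds shown here, compound 1 also sits at a limit, so no step between compound 1 and compound 4 can be read. Still open, from the compounds shown here alone, is whether butyl and sec-butyl on the double-bonded nitrogen differ in inhibition on this shared core.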